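Replacing (4-aminophenyl)amino with Piperazin-1-yl in Compound 2

The source may hold more compounds than are shown below. What is called first, only, known or untested is meant among the compounds shown, and "the series" means these compounds.

Compound 1 `N[C@H]1CC[C@H](Nc2c(C(=O)NCc3ccc(F)cc3)nc(N3CCCCC3)c3cccnc23)CC1`: in a functional assay on MDA-MB-435 cells (Homo sapiens) for cytotoxicity, read by MTT assay, with a stated time of 72 h (on this read-out higher numbers stand for weaker inhibition and lower numbers for stronger inhibition), compound 1 gives 5000 nM.
Compound 2 `Nc1ccc(Nc2c(C(=O)NCc3ccc(F)cc3)nc(Br)c3cccnc23)cc1`: in this assay compound 2 gives 7000 nM.
Compound 3 `C[C@H](CO)Nc1nc(C(=O)NCc2ccc(F)cc2)c(O)c2ncccc12`: in this assay compound 3 reaches only a limit, > 20000 nM.

Among the two compounds that returned a number, compound 2 holds the higher one, yet compound 1 sits only a short distance away and within the usual scatter, so no real order between the two can be claimed. The result for compound 3 is a limit rather than a number, and it marks (the limit of > 20000 nM in this assay, at which 1 of the 3 values shown sits). All three compounds are weak inhibitors on this read-out.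

Compound 4 `O=C(NCc1ccc(F)cc1)c1nc(Br)c2cccnc2c1N1CCNCC1` has not yet been tested. It arises from compound 2 through one change: piperazin-1-yl in place of (4-aminophenyl)amino on an aromatic carbon. The ring that leaves is aromatic with two hydrogen-bond donors; the ring that enters is non-aromatic with one donor. Within the data shown here, no pair of measured compounds differing in a single place is available here, so the size of such a step cannot be read directly from the data.

Since compound 2 gives 7000 nM and compound 1, which also carries a non-aromatic nitrogen-bearing ring, gives 5000 nM, the change is expected to move the number little, if at all, beyond the scatter. In this assay compound 4 is expected to give about 8000 nM, with a likely range from 2500 nM to 25000 nM. That corresponds to an expected step of a 1.1-fold higher number from compound 2 to compound 4 (0.06 log units; within the scatter), one that would stay within the scatter.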

Compound 4, half-maximal inhibitory concentration: 8000 nM
The estimate for compound 4 equals the measured number at the digits printed; measured number inside the range.
By their numbers in this assay, from the lowest: compounds 1, 2 and 4 (each within the scatter of the next). At a limit, above all of these: compound 3.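

Among these compounds, this is the first pair of measured compounds that differ in a single place, so the size of a change at this position can now be read directly rather than inferred from compounds that differ in several places. In this assay, placing piperazin-1-yl instead of (4-aminophenyl)amino on the aromatic carbon para to the bromo group amounts to a 1.1-fold higher number from compound 2 to compound 4 (0.06 log units; within the scatter) and so, for this pair, the read-out does not separate the aromatic ring that leaves from the non-aromatic ring that enters, even though the two groups differ in their hydrogen-bond donors. Nothing shown here bears on why this swap leaves the number where it is.

From the compounds shown here alone, both groups in this pair are cyclic and carry nitrogen, so it remains open whether something of a different kind on this aromatic carbon, such as a carboxylic acid or an open-chain amine like dimethylamino, would produce a step beyond the scatter. Going by these compounds, it is also open whether piperazin-1-yl would behave the same way if the bromo group were replaced by another group, such as a methoxy group.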